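Removing the Whole Cyclopropylmethyl from the Amide Nitrogen

The source may hold more compounds than are shown below. What is called first, only, known or untested is meant among the compounds shown, and "the series" means these compounds.

Compound 1 `CNC(=O)C1=CC(C)(C)Oc2ccc([N+](=O)[O-])cc21`: 61% in a functional assay on the whole organism (muscle tissue) with Rattus norvegicus as the target; on this read-out higher numbers stand for larger maximal responses and lower numbers for smaller maximal responses.
Compound 2 `CC1(C)C=C(C(=O)NCC2CC2)c2cc([N+](=O)[O-])ccc2O1`: 89.3% in this assay.

Compound 2 stands highest of the two numbers, with compound 1 below it: a number 28.3 percentage points higher from compound 1 to compound 2 (beyond the scatter). Compound 3 `CC1(C)C=C(C(N)=O)c2cc([N+](=O)[O-])ccc2O1` differs from compound 2 by hydrogen in place of cyclopropylmethyl on an amide-type nitrogen. Among the measured compounds shown here, the only measured step that bears on this is a number 28.3 percentage points higher from compound 1 to compound 2 (beyond the scatter), which runs the other way and was modest. Taking away the entire cyclopropylmethyl goes beyond simply undoing that step, so for compound 3 a drop beyond the scatter is expected, a number 39.3 percentage points lower from compound 2 to compound 3 (beyond the scatter). Compound 3 is therefore estimated at 50%, with a likely range from 25% to 75%.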

Compound 3, intrinsic activity: the largest response reached, in percent of the reference agonist's: 79.8%
Beside the measured number, compound 3's estimate is 29.8 percentage points below it, and the stated range ends below it.
By their numbers in this assay, from the lowest: compound 1; then compounds 3 and 2 (each within the scatter of the next).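

In this assay, the whole cyclopropylmethyl can leave the amide-type nitrogen without a change that stands clear of the scatter: a number 9.5 percentage points lower from compound 2 to compound 3 (within the scatter). Hydrogen in place of methyl does give a clear change: a number 18.8 percentage points higher from compound 1 to compound 3 (beyond the scatter), so among these three compounds the response does not follow the size of the group, and methyl gives the lowest number. No evidence here explains why methyl stands apart. Still open, from the compounds shown here alone, is whether ethyl would stay near methyl or match hydrogen and cyclopropylmethyl, and how a phenyl ring on this nitrogen would behave.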